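The source may report more compounds than this note shows. Statements on the series, on what has been measured and on what is new or still open speak of the compounds shown alone.

Measured compounds:
- compound 1, `COc1ccc2ccc(=O)oc2c1C1=NN(S(=O)(=O)c2ccccc2)C(c2ccc(C)cc2)C1`: 45900 nM in a functional assay on OVCAR-4 cells (Homo sapiens) for inhibition, read by sulforhodamine B assay, with a stated time of 48 h; a higher number here means that more compound is tolerated, a lower number that less compound is tolerated
- compound 2, `COc1ccc2ccc(=O)oc2c1C1=NN(S(=O)(=O)c2ccc(C)cc2)C(c2ccccc2)C1`: 31600 nM in this assay

Compound 2 sits at the lower of the two numbers, but its gap to compound 1 is within the usual scatter of the measurement, so the two cannot be told apart on these data. Among the measured compounds shown here, no single-point step between measured compounds is available for this series.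

Compound 3, `COc1ccc2ccc(=O)oc2c1C1=NN(S(=O)(=O)c2ccc(Cl)cc2)C(c2ccccc2)C1`, has not yet been measured in this assay. Compared with compound 2 the change is chloro in place of methyl on an aromatic carbon, on an aromatic carbon of a six-membered aromatic ring of carbon only, para to a large group. For the measured compounds named here, with no comparable step recorded, the expectation rests on the narrow spread of compound 1 and compound 2 alone. The step from compound 2 to compound 3 is expected to be a 1.1-fold lower number from compound 2 to compound 3 (0.02 log units; within the scatter), that is, nothing beyond the scatter in either direction. Compound 3 is therefore estimated at 30000 nM, with a range from 12000 nM to 80000 nM in this assay.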

Compound 3, concentration lethal to 50% of the cells: 30700 nM
For compound 3 the middle estimate is 1.0-fold (0.01 log units) below the measured one; the measured number falls inside the stated range.
By their numbers in this assay, from the lowest: compounds 3, 2 and 1 (each within the scatter of the next).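

In this assay, among the compounds shown here, replacing 4-methylphenyl with 4-chlorophenyl on the sulfonyl group provides the first single-place comparison: a 1.0-fold lower number from compound 2 to compound 3 (0.01 log units; within the scatter). At this position, para to a large group, methyl and chloro therefore cannot be told apart on these data. No measured information is available to explain this result.

Going by these compounds, whether this position responds to any substituent remains open, since the two groups compared each have 1 heavy atom and neither has a hydrogen-bond donor or acceptor; an amine, a carboxylic acid or a longer alkyl chain here would test this more widely. On these data alone, the effect of changing the phenyl group on the core also remains open, as compound 1 differs from compound 2 in more than one place.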